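Replacing the isopropoxy group of compound 1 with a carboxylic acid chain

The compounds below may be only part of what the source reports. "The series", "measured", "known", "first", "only" and "open" are said of these compounds alone.

Measured compounds:
compound 1 `CC(C)Oc1ccc(CNC(=O)c2ccc(C(C)(C)C)cc2)cc1`, 170 nM
compound 2 `CC(C)(C)c1ccc(C(=O)NCc2ccc(S(C)(=O)=O)cc2)cc1`, 3800 nM
compound 3 `CC(C)(C)c1ccc(C(=O)NCc2cccc(C(=O)O)c2)cc1`, 1700 nM

In an assay on HeLa cells with Bile acid receptor (Homo sapiens) as the target, read by a luciferase reporter, with a stated time of 24 h (a higher number here means that more compound is needed for the effect, a lower number that less compound is needed), compound 1 gives the lowest of the three numbers. Compound 3 gives 1700 nM. Compound 2 differs from compound 1 in a single place. Compound 2 gives 3800 nM, and the step of a 22-fold higher number from compound 1 to compound 2 (1.35 log units; beyond the scatter) shows how much the number rises when the isopropoxy group is exchanged.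

Compound 4 `CC(C)(C)c1ccc(C(=O)NCc2ccc(CCC(=O)O)cc2)cc1` is not yet measured. Relative to compound 1 its change is 2-carboxyethyl in place of isopropoxy on an aromatic carbon. Among the measured compounds shown here, the only directly comparable step is the exchange of the same isopropoxy group in compound 1 for methylsulfonyl, which gave a 22-fold higher number from compound 1 to compound 2 (1.35 log units; beyond the scatter). Compound 3, which carries a carboxylic acid but differs from compound 1 in more than one place, also sits well above compound 1. Both observations point the same way, so a step toward a higher number is expected for compound 4, though its size cannot be fixed closely from two comparisons. The estimated step is an 8.8-fold higher number from compound 1 to compound 4 (0.95 log units; beyond the scatter). Compound 4 is therefore expected to give 1500 nM, within a range of 400 nM to 6000 nM.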

Compound 4, half-maximal effective concentration: 350 nM
For compound 4 the middle estimate is 4.3-fold (0.63 log units) above the measured one; the measured number lies below the stated range.
By their numbers in this assay, from the lowest: compound 1; then compound 4; then compound 3; then compound 2.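

In this assay the position on an aromatic carbon, para to a large group, turns out to be far less sensitive to the loss of isopropoxy than the methylsulfonyl result alone suggested: 2-carboxyethyl in its place gives a 2.1-fold higher number from compound 1 to compound 4 (0.31 log units; beyond the scatter) and this is only a modest step, though it lies beyond the scatter. Exchanging methylsulfonyl for 2-carboxyethyl at the same position gives an 11-fold lower number from compound 2 to compound 4 (1.04 log units; beyond the scatter) and this large step shows that the replacement group, not just the removal of isopropoxy, sets the number here. A chain ending in a carboxylic acid is therefore accepted at this position, although compound 1 still keeps the lower number of the pair.

The compounds shown leave open whether the carboxylic acid at the end of the chain or the chain itself accounts for the difference from methylsulfonyl, which a plain propyl chain or a methyl ester would help to separate. They also leave open whether a longer chain ending in a carboxylic acid, or a chain ending in an amine, would match or pass compound 1, and no measurement given here offers an explanation for the gap between these groups.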